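A longer chain on compound 1: what to expect

A few compounds are considered here, and "the series" means these few. Any claim that something is new, unique, unknown or untested is made for them only; others in the source may bear on it.

Measured in a functional assay, read by fluorescence and spectrophotometry, with a stated time of 1 h; a higher number here means that more compound is needed for the effect, a lower number that less compound is needed:
- Compound 1 `CCCCCCS(=O)(=O)/C=C/c1ccc(O)c(O)c1` gives 7300 nM
- Compound 2 `O=S(=O)(/C=C/c1ccc(O)c(O)c1)CC1CCCCO1` gives 10800 nM
- Compound 3 `CCCCCCCCCCCS(=O)(=O)/C=C/c1ccc(O)c(O)c1` has not yet been measured

Among the compounds with values here, compound 1 has only one measured neighbour, compound 2, and their two values lie within the scatter of each other. Neither can be ranked above the other. Compound 3 keeps the core of compound 1 and differs only in its chain, with pentyl in place of hydrogen on a saturated chain carbon, six bonds along the chain from a sulfonyl sulfur. Within the data shown here, the only measured step is a 1.5-fold higher number from compound 1 to compound 2 (0.17 log units; within the scatter). It placed oxan-2-yl in place of pentyl and did not lengthen the chain, so it bears only loosely on this change and gives no direction. No step beyond the scatter is therefore expected in this assay, although so little data leaves real uncertainty. Compound 3 is expected at 6500 nM, with an estimated range of 2000 nM to 20000 nM. This estimate means an expected 1.1-fold lower number from compound 1 to compound 3 (0.05 log units; within the scatter).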

Compound 3, half-maximal effective concentration: 11400 nM
Compound 3: middle estimate off by 1.8-fold (0.24 log units), on the low side; low and high end bracket the measured number.
By their numbers in this assay, from the lowest: compounds 1, 2 and 3 (each within the scatter of the next).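

In this assay, within the data shown here, the pentyl added on a saturated chain carbon, six bonds along the chain from a sulfonyl sulfur, gives a 1.6-fold higher number from compound 1 to compound 3 (0.19 log units; within the scatter) and this is the first measured change of chain length on the shared core. The five added carbon atoms leave the number of compound 3 indistinguishable from that of compound 1, so the two compounds cannot be ranked against each other, and a much longer chain at this position has produced no real shift in this assay. Nothing measured here accounts for this outcome.

On these data alone, whether a chain of intermediate length, such as octyl, would behave like these two remains open, as does what a chain ending in an amine or a carboxylic acid would give at this position. It also remains open whether any change at this position can move the number beyond the scatter at all, and no step shown so far does so.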